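The source may report more compounds than this note shows. Statements on the series, on what has been measured and on what is new or still open speak of the compounds shown alone.

Measured compounds:
Compound 1, `O=C(NC1CCCC(NC(=O)c2cccc(Cl)c2)C1)c1cccc(Cl)c1`, 139 nM
Compound 2, `Cc1cccnc1C(=O)N[C@H]1CCC[C@H](NC(=O)c2cccc(Cl)c2)C1`, 7840 nM

The two measured compounds share the same core and differ in the substituent on one of the two amide groups. In a functional assay on HEK293 cells for antagonist activity at metabotropic glutamate receptor 5 (Homo sapiens), read by FLIPR and calcium flux (a higher number here means a weaker inhibitor, a lower number a stronger inhibitor), compound 1 gives 139 nM, the lowest of the two numbers, while compound 2 gives 7840 nM, a far higher number that lies beyond the scatter. For the measured compounds named here, no pair of measured compounds differs in one place, so no single-change step is known from the numbers themselves.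

Compound 3, `CN(C(=O)c1cccc(Cl)c1)C1CCCC(NC(=O)c2cccc(Cl)c2)C1`, has not been measured. It is derived from compound 1 by one change: methyl in place of hydrogen on an amide-type nitrogen. Going by the values given here, with no measured step of this kind to lean on, the expectation rests only on the compounds given. Compound 3 is expected to be a weaker inhibitor than compound 1, and the step of an 18-fold higher number from compound 1 to compound 3 (1.25 log units; beyond the scatter) is expected to lie beyond the scatter. Compound 3 is estimated at 2500 nM, within a range from 400 nM to 15000 nM.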

Compound 3, half-maximal inhibitory concentration: > 10000 nM
Compound 3: no number, only a limit; the forecaster's own chance of this, stated with the estimate: 10%; middle value at least 4.0-fold (0.60 log units) from the limit.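

For the compounds shown here, the change of methyl in place of hydrogen on an amide-type nitrogen gives the first step in this set that differs in one place: an at least 71-fold higher number from compound 1 to compound 3 (1.85 log units; beyond the scatter). A single added carbon at this nitrogen, whose other neighbours are a carbonyl carbon and a saturated ring carbon, is therefore enough to move the number far beyond the scatter, so the amide hydrogen cannot be swapped for methyl here without a large loss of inhibition. In this assay compound 3 gives > 10000 nM, which is a limit of the assay and not a number, so the full size of the step stays unknown: the limit of > 10000 nM in this assay, at which 1 of the 3 values shown sits.

The compounds shown leave open whether an ethyl group or a longer chain on this nitrogen would behave the same way. They also leave open what methyl would do on the other amide nitrogen.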